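The source may hold more compounds than are shown below. What is called first, only, known or untested is meant among the compounds shown, and "the series" means these compounds.

Measured so far:
compound 1 `COc1ccccc1/C=C(/SCc1ccc(Cl)c(Cl)c1)C(=O)c1ccc(Cl)cc1`: 10000 nM
compound 2 `O=C(/C(=C\c1c[nH]c2ccccc12)Sc1ccc(Br)cc1)c1ccc(Br)cc1`: 1000 nM
compound 3 `COc1ccc(OC)c(/C=C(/SCc2ccc(Cl)c(Cl)c2)C(=O)c2ccc(Cl)cc2)c1`: 10000 nM

In a functional assay on DU-145 cells (Homo sapiens) for inhibition, read by trypan blue exclusion, with a stated time of 96 h (on this read-out lower numbers stand for stronger inhibition of growth and higher numbers for weaker inhibition of growth), compound 2 gives the lowest number of the three; compounds 1 and 3 both lie beyond the scatter above it. The difference between the core of compound 1 and the core of compound 2 is not broken down here. Compounds 1 and 3 differ by methoxy in place of hydrogen on an aromatic carbon, and that change gave no change at the digits printed from compound 1 to compound 3 (within the scatter).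

Compound 4 `COc1ccc2[nH]cc(/C=C(/Sc3ccc(Br)cc3)C(=O)c3ccc(Br)cc3)c2c1` differs from compound 2 by methoxy in place of hydrogen on an aromatic carbon. This is the same kind of change, not the same: in compound 3 the methoxy sits on a six-membered ring of carbon only, meta to a large group and para to a methoxy group, whereas in compound 4 it sits on a ring that is part of a fused system of two rings, meta and para to a fused ring. Because no change at the digits printed from compound 1 to compound 3 (within the scatter) showed no change, the step is expected to be no change at the digits printed from compound 2 to compound 4 (within the scatter). Compound 4 is therefore estimated at 1000 nM, between 400 nM and 3000 nM.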

Compound 4, concentration for 50% growth inhibition: 10000 nM
For compound 4 the middle estimate is 10-fold (1.00 log units) below the measured one; measured number outside the range, above it.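

In this assay, methoxy in place of hydrogen on an aromatic carbon gave a 10-fold higher number from compound 2 to compound 4 (1.00 log units; beyond the scatter), so on the core of compound 2 this change weakened growth inhibition. The change therefore does not carry over with the same effect from one core to the other: the same change on two cores in this assay, no change at the digits printed (within the scatter) from compound 1 to compound 3 and a 10-fold higher number (1.00 log units; beyond the scatter) from compound 2 to compound 4, 10-fold (1.00 log units) apart, beyond the scatter of two such steps. These two pairs do not show why the steps differ, since the methoxy also sits at a different place on each core, and two pairs cannot separate the core from that place.

Open, on these data alone, is whether a hydroxyl group, fluorine or an amine at the same place on the core of compound 2 would give a step like that of methoxy. Also open, as far as these compounds go, is how methoxy would behave elsewhere on that ring.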